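This account rests on a few compounds, and the source may have more. Where it says the series, first, only, none or still open, it means among the compounds named here.

In a functional assay on HCT-116 cells (Homo sapiens) for cytotoxicity, with a stated time of 3 days (a higher number here means a weaker inhibitor, a lower number a stronger inhibitor), compound 1 `C=Cc1csc(Br)n1` gives > 40000 nM, which is a limit of the assay and not a number. Compound 2 `CC#Cc1nc(C(=O)OCC)cs1` gives > 40000 nM, which is also a limit. Compound 3 `C#Cc1nc(C(=O)Nc2ccccc2)cs1`, by contrast, gives a true number of 4880 nM. Compound 1 therefore stands at the limit of > 40000 nM in this assay, at which 2 of the 3 values shown sit.

Compound 4 `C#Cc1csc(Br)n1` has not yet been measured. It keeps the core of compound 1 and the bromo group, and makes one change: ethynyl in place of vinyl on an aromatic carbon. The swap is small, and the two groups have the same number of heavy atoms.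

Within the data shown here, no measured pair shows this swap on its own, so its size in this assay has to be judged with caution. Compound 3 carries an ethynyl group and gives 4880 nM, but it differs from compound 1 in more than the swapped group, so it offers only a weak hint. A modest move towards stronger inhibition is expected, and compound 4 may well remain at the limit. The expected change is an at least 1.3-fold lower number from compound 1 to compound 4 (0.12 log units; that floor lies within the scatter), and this is only an estimate. The estimated value for compound 4 is 30000 nM, with an expected range from 10000 nM to 80000 nM.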

Compound 4, half-maximal inhibitory concentration: > 40000 nM
Compound 4: only a limit was reported (the forecaster's own chance of this, stated with the estimate: 60%); middle value at least 1.3-fold (0.12 log units) from the limit.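

Compound 1 and compound 4 both give only a limit in this assay, not a true number, so the step between them cannot be read: the limit of > 40000 nM in this assay, at which 3 of the 4 values shown sit.

The compounds shown leave open how much, if at all, ethynyl in place of vinyl on an aromatic carbon shifts the half-maximal inhibitory concentration.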